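Thiophen-3-yl for 4-nitrophenyl: notes on the series

This account rests on a few compounds, and the source may have more. Where it says the series, first, only, none or still open, it means among the compounds named here.

Measured in a functional assay on B16-F10 cells (Mus musculus) for antiproliferative activity, read by MTT assay, with a stated time of 48 h; a lower number here means a stronger inhibitor, a higher number a weaker inhibitor:
- compound 1 `CC(=O)N1N=C(c2ccc3ccccc3c2)OC1c1ccccc1F` gives 6.05 ug/mL
- compound 2 `CC(=O)N1N=C(c2ccc3ccccc3c2)OC1c1ccc([N+](=O)[O-])cc1` gives 9.32 ug/mL

Among the measured compounds shown here, compound 2, at 9.32 ug/mL, lies within the scatter of compound 1, the only other measured compound, so the two cannot be ranked in this assay. The next structure is compound 3 `CC(=O)N1N=C(c2ccc3ccccc3c2)OC1c1ccsc1`, where thiophen-3-yl stands in place of 4-nitrophenyl on a saturated ring carbon of the shared core: thiophen-3-yl in place of 4-nitrophenyl on a saturated ring carbon.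

For the measured compounds named here, only one measured step bears on this change: a 1.5-fold higher number from compound 1 to compound 2 (0.19 log units; within the scatter). That step also replaces the group at this same carbon, and it stays within the scatter. Going by the values given here, it is thin evidence, since it exchanges one substituted phenyl for another and no thiophene-bearing compound has yet been measured. No step beyond the scatter is therefore expected in this assay, and no direction can be argued with confidence. The expected change is a 1.2-fold lower number from compound 2 to compound 3 (0.09 log units; within the scatter). For compound 3 the estimated value is 7.5 ug/mL, with an expected range of 3.5 ug/mL to 16 ug/mL.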

Compound 3, half-maximal inhibitory concentration: 8.56 ug/mL
Compound 3: the middle estimate sits 1.1-fold (0.06 log units) below what was measured; low and high end bracket the measured number.
By their numbers in this assay, from the lowest: compounds 1, 3 and 2 (each within the scatter of the next).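

In this assay the first five-membered aromatic ring at this saturated ring carbon gives a 1.1-fold lower number from compound 2 to compound 3 (0.04 log units; within the scatter) and, set against 2-fluorophenyl, a 1.4-fold higher number from compound 1 to compound 3 (0.15 log units; within the scatter) and both steps stay within the scatter. Earlier, this carbon had been seen to carry only substituted phenyl groups; thiophen-3-yl now shows that a ring with a sulfur atom and without any substituent can stand there with no readable step, so compounds 1, 2 and 3 cannot be ranked against one another. Nothing at hand accounts for this result.

From the compounds shown here alone, all three groups compared at this carbon are aromatic rings, so it remains open whether an amine, a carboxylic acid or a saturated ring such as morpholine in their place would give a step beyond the scatter. Going by these compounds, the acetyl group on the neighbouring ring atom is common to all three compounds, and the effect of a longer chain in its place also remains open.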